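The source may hold more compounds than are shown below. What is called first, only, known or untested is meant among the compounds shown, and "the series" means these compounds.

Measured so far in a physicochemical assay for lipophilicity, read by HPLC, at pH 7.5 (on this read-out lower numbers stand for lower lipophilicity and higher numbers for higher lipophilicity), for three compounds:
- Compound 1 `CC[C@@H](Nc1c(C#N)c(-c2ccc(-c3ncccc3C)cc2)nc2cnccc12)C(N)=O` gives 2
- Compound 2 `CC[C@@H](Nc1c(C#N)c(-c2ccc(-c3cnccc3C)cc2)nc2cnccc12)C(N)=O` gives 2
- Compound 3 `CC[C@@H](Nc1c(C#N)c(-c2ccc(Br)cc2)nc2cnccc12)C(N)=O` gives 2.2

Going by the values given here, compound 3 stands with the other two: a number 0.20 log units higher from compound 1 to compound 3 (within the scatter) and a number 0.20 log units higher from compound 2 to compound 3 (within the scatter) are the only steps involving bromo, and no change at the digits printed from compound 1 to compound 2 (within the scatter) separates the two methylpyridinyl compounds. In compound 4 `CC[C@@H](Nc1c(C#N)c(-c2ccc(-c3ccccc3OC)cc2)nc2cnccc12)C(N)=O`, 2-methoxyphenyl replaces bromo on an aromatic carbon, para to a large group (2-methoxyphenyl in place of bromo on an aromatic carbon). Among the compounds with values here, no measured step places a ring of carbon only here, so these steps guide only loosely. The entering ring, unlike the methylpyridinyl rings, holds carbon only, so a modest rise seems likely. The expected change is a number 0.40 log units higher from compound 3 to compound 4 (beyond the scatter) by estimate, and it may barely clear the scatter. Compound 4 is estimated at 2.6 (expected range 2.2 to 3.1) when measured.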

Compound 4, distribution coefficient: 2.7
Beside the measured number, compound 4's estimate is 0.10 log units below it; measured number inside the range.
By their numbers in this assay, from the lowest: compounds 1, 2 and 3 (each within the scatter of the next); then compound 4.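

Swapping groups on this aromatic carbon can shift the number in this assay beyond the scatter, which no step among the earlier compounds did: bromo gives way to 2-methoxyphenyl with a number 0.50 log units higher from compound 3 to compound 4 (beyond the scatter) as the result. The carbon-only ring also separates from both methylpyridinyl rings, with a number 0.70 log units higher from compound 2 to compound 4 (beyond the scatter) and a number 0.70 log units higher from compound 1 to compound 4 (beyond the scatter) as the two steps here. Nothing at hand gives a cause for these steps.

Still open, going by these compounds, is whether the ring itself or its methoxy group carries the rise. A plain phenyl ring, or a ring bearing an amine or a carboxylic acid, could help separate these possibilities.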